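An Amide Aryl Exchange Awaiting Its Cytotoxicity Number

The source may hold more compounds than are shown below. What is called first, only, known or untested is meant among the compounds shown, and "the series" means these compounds.

Measured compounds:
compound 1: `CCn1cc(-c2nc3ccc([N+](=O)[O-])cc3o2)c(=O)c2cc(F)c(N3CCNC(C)C3)c(F)c21`, 2000 nM
compound 2: `CCn1cc(C(=O)Nc2ccc(Cl)cn2)c(=O)c2cc(F)c(N3CCNC(C)C3)c(F)c21`, 4800 nM

In a functional assay on MDA-MB-231 cells (Homo sapiens) for cytotoxicity, read by MTT assay (a higher number here means a weaker inhibitor, a lower number a stronger inhibitor), compound 1 gives 2000 nM and compound 2 gives 4800 nM. Compound 2 thus stands at the higher of the two numbers, and its gap to compound 1 lies beyond the usual scatter of repeated measurements.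

Compound 3 `CCn1cc(C(=O)Nc2cc([N+](=O)[O-])ccc2F)c(=O)c2cc(F)c(N3CCNC(C)C3)c(F)c21` has not yet been measured. It differs from compound 2 in one place: 2-fluoro-5-nitrophenyl in place of 5-chloropyridin-2-yl on an amide-type nitrogen. For the measured compounds named here, no measured pair in this set shows this exchange, so its effect cannot be read from a direct comparison. The shared core is kept and only the group on the amide nitrogen changes; a step of modest size is expected, possibly none beyond the scatter, with the direction open. The step is expected to be a 1.4-fold lower number from compound 2 to compound 3 (0.14 log units; within the scatter). The estimate for compound 3 in this assay is 3500 nM, within a range of 1200 nM to 10000 nM.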

Compound 3, half-maximal inhibitory concentration: 6900 nM
Estimate against measurement, compound 3: 2.0-fold (0.29 log units) below; the range from low to high includes it.
By their numbers in this assay, from the lowest: compound 1; then compounds 2 and 3 (each within the scatter of the next).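

In this assay, putting 2-fluoro-5-nitrophenyl in place of 5-chloropyridin-2-yl on the amide-type nitrogen gives a 1.4-fold higher number from compound 2 to compound 3 (0.16 log units; within the scatter), so this exchange has no effect that can be told from the scatter. At this position, then, a six-membered aromatic ring of carbon only stands in for one with a hetero atom, with no readable gain or loss in cytotoxicity. Nothing on hand accounts for this result.

The compounds shown leave open whether the fluorine or the nitro group matters on its own, which a plain phenyl on the amide nitrogen would begin to separate. They also leave open whether a group of another kind there, such as an alkyl chain, an amine or a carboxylic acid, would move the number beyond the scatter.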